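A few compounds are considered here, and "the series" means these few. Any claim that something is new, unique, unknown or untested is made for them only; others in the source may bear on it.

Compound 1 `O=C(CSc1nc2ccc(NC(=O)CCl)cc2s1)NCc1ccccc1` gives 4200 nM in a functional assay on MCF7 cells (Homo sapiens) for cytotoxicity, read by MTT assay, with a stated time of 48 h; a lower number here means a stronger inhibitor, a higher number a weaker inhibitor. Compound 2 `COc1ccc(CNC(=O)CSc2nc3ccc(NC(=O)CCl)cc3s2)cc1` gives 5100 nM in this assay, a step of a 1.2-fold higher number from compound 1 to compound 2 (0.08 log units; within the scatter) for the change (methoxy in place of hydrogen on an aromatic carbon). Compound 3 `O=C(CSc1nc2ccc(NC(=O)c3ccc([N+](=O)[O-])cc3)cc2s1)NCc1ccccc1` sits at a limit of this assay, > 100000 nM, rather than at a number. The step from compound 1 to compound 3 is an at least 23-fold higher number from compound 1 to compound 3 (1.37 log units; beyond the scatter), for the change (4-nitrophenyl in place of chloromethyl on a carbonyl carbon), which is also how the cores of compound 3 and compound 4 differ from those of compound 1 and compound 2. Compound 4 `COc1ccc(CNC(=O)CSc2nc3ccc(NC(=O)c4ccc([N+](=O)[O-])cc4)cc3s2)cc1` carries the change (methoxy in place of hydrogen on an aromatic carbon), the same change made from compound 1 to compound 2. In this assay a step of a number no higher from compound 3 to compound 4 (the limit leaves the size open) is expected, resting on the small step of a 1.2-fold higher number from compound 1 to compound 2 (0.08 log units; within the scatter) and on compound 3 standing at the limit of > 100000 nM in this assay, at which 1 of the 3 values shown sits. Compound 4 is therefore estimated at 100000 nM.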

Compound 4, half-maximal inhibitory concentration: > 100000 nM
Compound 4: only a limit was reported; the forecaster's own chance of this, stated with the estimate: 85%; the middle value sits exactly at the limit.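

Putting 4-nitrophenyl in place of chloromethyl on the carbonyl carbon gives, in this assay, an at least 19-fold higher number from compound 2 to compound 4 (1.29 log units; beyond the scatter), so the large step seen on the core of compound 1 appears again on a second core: the same change on two cores in this assay, an at least 23-fold higher number (1.37 log units; beyond the scatter) from compound 1 to compound 3 and an at least 19-fold higher number (1.29 log units; beyond the scatter) from compound 2 to compound 4; the limit leaves it open whether they differ The direction of the change therefore carries over between these two cores, but its exact size cannot be compared. The step for methoxy between the two compounds carrying 4-nitrophenyl cannot be read, so whether methoxy matters on that core remains unknown, because both values are limits: the limit of > 100000 nM in this assay, at which 2 of the 4 values shown sit.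

The compounds shown leave open whether removing chloromethyl or adding 4-nitrophenyl drives the large step. A plain phenyl, a 4-aminophenyl or a longer chloroalkyl chain on the carbonyl carbon could help separate these two parts of the change.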